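Methoxy for cyano on the pyridine of compound 3

A few compounds are considered here, and "the series" means these few. Any claim that something is new, unique, unknown or untested is made for them only; others in the source may bear on it.

Three compounds have numbers in a functional assay on HEK293 cells for agonist activity at Neuronal acetylcholine receptor; alpha4/beta2 (Homo sapiens), read by FLIPR (on this read-out lower numbers stand for an effect already at smaller amounts and higher numbers for an effect only at larger amounts of compound), so far. Compound 1 `COc1cc(N2C[C@H]3CCNC[C@H]32)cnc1Br` gives 200 nM. Compound 2 `N#Cc1cncc(N2C[C@@H]3CCNC[C@@H]32)c1` gives 2190 nM, and its mirror image compound 3 `N#Cc1cncc(N2C[C@H]3CCNC[C@H]32)c1` gives 1930 nM. Compound 3 thus stands second highest of the three, with compound 2 within the scatter of it and compound 1 clearly lower, beyond the scatter. For the measured compounds named here, the only measured step is a 1.1-fold lower number from compound 2 to compound 3 (0.05 log units; within the scatter), which does not move the number, in line with the fact that compounds 2 and 3 differ only in the configuration as drawn.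

Compound 4 `COc1cncc(N2C[C@H]3CCNC[C@H]32)c1` differs from compound 3 by methoxy in place of cyano on an aromatic carbon. Going by the values given here, no measured step covers this exchange: compound 1 carries a methoxy on its ring but also a bromine and a different ring arrangement, so no step to it exists and its value can only be noted alongside that of compound 3. The inversion step from compound 2 to compound 3 tells nothing about a substituent swap. Among the compounds with values here, with no direct precedent, the expected size of the step in this assay from compound 3 to compound 4 is taken as a moderate decrease, a 2.8-fold lower number from compound 3 to compound 4 (0.44 log units; beyond the scatter), with wide uncertainty. Compound 4 is accordingly estimated at 700 nM, within a range from 200 nM to 2500 nM.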

Compound 4, half-maximal effective concentration: 1110 nM
The estimate for compound 4 lay 1.6-fold (0.20 log units) below the measured number; the range from low to high includes it.
By their numbers in this assay, from the lowest: compound 1; then compounds 4, 3 and 2 (each within the scatter of the next).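

At this aromatic carbon, two atoms from the ring nitrogen, methoxy and cyano cannot be told apart in this assay: the exchange reads as a 1.7-fold lower number from compound 3 to compound 4 (0.24 log units; within the scatter), even though the two groups have different atoms and shapes of bond. The larger difference lies elsewhere. Compound 4 now links compound 1 to the rest of the series: with methoxy and the core held constant, hydrogen in place of bromo gives a 5.6-fold higher number from compound 1 to compound 4 (0.74 log units; beyond the scatter), the only new step beyond the scatter, so among these compounds the low number of compound 1 goes with the bromo group and not with methoxy alone. Nothing available on these compounds gives a cause for either step.

Open, going by these compounds, is whether the bromo step carries over to the cyano compounds, and whether the mirror image of compound 4 or of compound 1 matches its partner as closely as compounds 2 and 3 do. Also open, on these data alone, is how far the position two atoms from the ring nitrogen tolerates groups of another kind, such as an amine, a carboxylic acid or a longer alkoxy chain.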